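Swapping the fluorophenyl arm of compound 2

A few compounds are considered here, and "the series" means these few. Any claim that something is new, unique, unknown or untested is made for them only; others in the source may bear on it.

The measured compounds in a functional assay on T47D cells (Homo sapiens) for inhibition; a lower number here means a stronger inhibitor, a higher number a weaker inhibitor:
- compound 1, `Oc1ccccc1-c1cc(-c2cccc(F)c2)cc(-c2ccccc2O)n1`, gives > 50000 nM, which is a limit of the assay and not a number.
- compound 2, `Oc1cccc(-c2cc(-c3cccc(F)c3)cc(-c3ccccc3O)n2)c1`, gives > 50000 nM, again only a limit.
- compound 3, `Oc1ccc(-c2cc(-c3cccc(F)c3)cc(-c3cccc(O)c3)n2)cc1`, gives 3510 nM.

Compound 2 therefore stands at the limit, as described in the limit of > 50000 nM in this assay, at which 2 of the 3 values shown sit, and its position relative to compound 1 cannot be read: the step that the two limits leave unreadable from compound 1 to compound 2 is unreadable because both values are limits. Only an at least 14-fold lower number from compound 2 to compound 3 (1.15 log units; beyond the scatter) gives a readable step, and it concerns the hydroxyphenyl groups, not the fluorophenyl arm.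

Compound 4, `Oc1cccc(-c2cc(-c3ccc(C(F)(F)F)cc3)cc(-c3ccccc3O)n2)c1`, differs from compound 2 by 4-(trifluoromethyl)phenyl in place of 3-fluorophenyl on an aromatic carbon. Among the measured compounds shown here, neither of the two measured steps touches this arm, so no measured step bears directly on the change; both measured steps alter a hydroxyphenyl group instead. For the measured compounds named here, the only guide is that compound 2 itself sits at the limit, and the 3-hydroxyphenyl and 2-hydroxyphenyl groups that compound 2 carries are kept in compound 4. On that basis compound 4 is expected to stay at or near the limit, with the step that the limit leaves unreadable from compound 2 to compound 4 estimated as no clear change beyond the scatter. The estimate for compound 4 in this assay is 60000 nM, spanning 15000 nM to 250000 nM.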

Compound 4, half-maximal inhibitory concentration: > 50000 nM
Compound 4 was reported as a limit; the forecaster's own chance of this, stated with the estimate: 75%; the middle value is on the limit's open side.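

In this assay compound 4 gives > 50000 nM and that is a limit of the assay, not a number. Compound 2 also stands at a limit, so no step between compound 2 and compound 4 can be read: the limit of > 50000 nM in this assay, at which 3 of the 4 values shown sit.

Among the compounds shown here, still open is whether 4-(trifluoromethyl)phenyl in place of 3-fluorophenyl changes inhibition at all, and how it would fare with the hydroxyphenyl groups of compound 3, the only compound here with a readable number.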